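The source may report more compounds than this note shows. Statements on the series, on what has been measured and on what is new or still open speak of the compounds shown alone.

Working notes on the series. Compound 1 `C=CCONC(=O)CN1C(=O)S/C(=C\c2ccc(C(=O)N[C@@H](CC(C)C)C(=O)OC)cc2)C1=O` returns only a limit in a functional assay on RAW264.7 cells (Mus musculus) for inhibition, read by microscopy and resazurin assay, with a stated time of 72 h (on this read-out higher numbers stand for weaker inhibition and lower numbers for stronger inhibition), namely > 128000 nM. Compound 2 `C=CCONC(=O)Cn1ccc(C(=O)NCC(=O)N[C@@H](CC(C)C)C(=O)O)c1` likewise gives only a limit in this assay, > 128000 nM. Compound 3 `C=CCONC(=O)Cn1ccc(C(=O)N[C@@H](C)C(=O)N[C@@H](CC(C)C)C(=O)O)c1` also gives only a limit there, > 128000 nM. The step that the two limits leave unreadable from compound 2 to compound 3 therefore cannot be read, and the limit of > 128000 nM in this assay, at which 3 of the 3 values shown sit, is the whole of what the numbers show. Compound 4 `CC(C)C[C@H](NC(=O)CNC(=O)c1ccn(CC(=O)NOCc2ccccc2)c1)C(=O)O` differs from compound 2 by phenyl in place of vinyl on a saturated chain carbon bound to an oxygen on an unsaturated carbon. Among the compounds with values here, no measured step bears on this change; every value so far sits at the same limit, so no size of step in this assay can be expected from the numbers, in either direction, and a further limit is the likeliest outcome. Compound 4 is estimated at 128000 nM, between 30000 nM and 500000 nM. The expected step is a number no higher from compound 2 to compound 4 (the limit leaves the size open).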

Compound 4, half-maximal inhibitory concentration: > 128000 nM
Compound 4 was reported as a limit; the forecaster's own chance of this, stated with the estimate: 85%; the middle value lies on the limit itself.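

Within the data shown here, no step from compound 2 to compound 4 can be read in this assay because both values are limits: the limit of > 128000 nM in this assay, at which 4 of the 4 values shown sit.
The compounds shown leave open how large the change from vinyl to phenyl is, and which change in the series would give a value that is not a limit.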